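Swapping the (4-bromophenyl)amino group for chloro

A few compounds are considered here, and "the series" means these few. Any claim that something is new, unique, unknown or untested is made for them only; others in the source may bear on it.

Measured in a functional assay on microsomes from liver (Rattus norvegicus, strain Wistar) for inhibition, with a stated time of 15 min; a higher number here means a weaker inhibitor, a lower number a stronger inhibitor:
Compound 1 `COc1cc(C2CC(c3cc4ccccc4o3)=NN2C(=O)Nc2ccccc2O)ccc1O`: 22000000 nM
Compound 2 `COc1cc(C2CC(c3cc4ccccc4o3)=NN2C(=O)Nc2ccc(Br)cc2)ccc1O`: 115000000 nM

Of these two, compound 2 has the higher number, 115000000 nM, which makes it the weaker inhibitor of the pair. Compound 3 `COc1cc(C2CC(c3cc4ccccc4o3)=NN2C(=O)Cl)ccc1O` keeps the shared core and changes only what sits on a carbonyl carbon: chloro in place of (4-bromophenyl)amino on a carbonyl carbon. Among the measured compounds shown here, one measured step bears on this change: a 5.2-fold higher number from compound 1 to compound 2 (0.72 log units; beyond the scatter). That step swapped one substituted phenyl group for another, while compound 3 carries chloro and no such ring, so it is only a rough guide. A step of similar modest size is expected in this assay. A lower number seems likelier, since compound 2 at 115000000 nM is the higher of the two, but the direction is uncertain. The expected change is a 2.3-fold lower number from compound 2 to compound 3 (0.36 log units; beyond the scatter). The estimate for compound 3 is 50000000 nM, with an expected range from 10000000 nM to 200000000 nM.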

Compound 3, half-maximal inhibitory concentration: 147000000 nM
Compound 3: middle estimate off by 2.9-fold (0.47 log units), on the low side; measured number inside the range.
By their numbers in this assay, from the lowest: compound 1; then compounds 2 and 3 (each within the scatter of the next).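

In this assay, chloro in place of (4-bromophenyl)amino on a carbonyl carbon gives a 1.3-fold higher number from compound 2 to compound 3 (0.11 log units; within the scatter), so the whole aromatic ring and its hydrogen-bond donor can leave this position without a change beyond the scatter. Set against the (2-hydroxyphenyl)amino group, the same chloro gives a 6.7-fold higher number from compound 1 to compound 3 (0.82 log units; beyond the scatter), which leaves compound 1 as the strongest inhibitor of the three and shows that a ring at this position does not by itself set the number. Nothing measured here explains these results.

Whether the gap belongs to the hydroxy group of compound 1 stays open, since plain phenylamino does not appear among these compounds. Also open, as far as these compounds go, is how a simple amine or a longer alkyl chain on this carbonyl carbon would compare.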